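This account rests on a few compounds, and the source may have more. Where it says the series, first, only, none or still open, it means among the compounds named here.

Measured compounds:
Compound 1, `Cc1ccc(-c2cn(/N=C/c3cc4ccccc4nc3Cl)c(N)n2)cc1`: in a functional assay on MDA-MB-231 cells (Homo sapiens) for cytotoxicity, read by MTT assay, with a stated time of 48 h (on this read-out lower numbers stand for stronger inhibition and higher numbers for weaker inhibition), compound 1 gives only a limit, > 50000 nM.
Compound 2, `Cc1ccc(-c2cn(/N=C/c3cc4cc(C)ccc4nc3Cl)c(N)n2)cc1`: in this assay compound 2 gives 22300 nM.
Compound 3, `Nc1nc(-c2cccc3ccccc23)cn1/N=C/c1cc2ccccc2nc1Cl`: in this assay compound 3 gives only a limit, > 50000 nM.

Among the compounds with values here, compound 2 therefore holds the only number among the three results; the other two are limits, as the limit of > 50000 nM in this assay, at which 2 of the 3 values shown sit, records. Within the data shown here, the single measured step, an at least 2.2-fold lower number from compound 1 to compound 2 (0.35 log units; beyond the scatter), turns a limit into a number, so only its lower bound is known.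

Compound 4, `Cc1ccc2nc(Cl)c(/C=N/n3cc(-c4cccs4)nc3N)cc2c1`, differs from compound 2 by thiophen-2-yl in place of 4-methylphenyl on an aromatic carbon. Among the measured compounds shown here, no measured step touches this place: the one step known changes a group on the other ring system. Compound 3, which carries a different group at this same place, sits at the limit. So the data give no direction for this change, and no step beyond the scatter can be argued for from them.

The step from compound 2 to compound 4 is therefore expected to be small, a 1.6-fold higher number from compound 2 to compound 4 (0.20 log units; within the scatter), with a real chance that compound 4 again reports only a limit. Compound 4 is estimated at 35000 nM in this assay, with a range from 12000 nM to 100000 nM.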

Compound 4, half-maximal inhibitory concentration: > 50000 nM
Compound 4: no number, only a limit; the forecaster's own chance of this, stated with the estimate: 45%; at least 1.4-fold (0.15 log units) between middle value and limit.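

Within the data shown here, this is the first readable step at this place on the five-membered aromatic ring with 2 nitrogen: an at least 2.2-fold higher number from compound 2 to compound 4 (0.35 log units; beyond the scatter). With the rest of compound 2 kept, the number in this assay therefore depends on the group here, and thiophen-2-yl does not retain the measurable result seen with 4-methylphenyl. Compound 2 remains the only one of the four with a number, so the step gives only a lower bound, and the series now sits mostly at one ceiling: the limit of > 50000 nM in this assay, at which 3 of the 4 values shown sit.

The compounds shown leave open which feature of the exchange matters, as the single step replaces a six-membered aromatic ring of carbon only with a five-membered one holding sulfur and also removes the methyl group. They also leave open whether a 4-methoxyphenyl group, a 4-chlorophenyl group or a pyridin-3-yl ring at this place would give a number in this assay near that of compound 2, or one beyond it, and whether the methyl step seen on the other side of the core would carry over to such groups.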